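The source may hold more compounds than are shown below. What is called first, only, known or untested is meant among the compounds shown, and "the series" means these compounds.

Series notes. Among the compounds with values here, the shared core of compound 1 `S=C(Nc1ccccc1)N1N=C(c2ccc(Cl)cc2)CC1c1ccc2c(c1)OCCO2` carries a varied aryl on the carbon with a double bond to nitrogen, and all values so far come from a functional assay on A-375 cells (Homo sapiens) for antiproliferative activity, read by MTT assay, with a stated time of 48 h; on this read-out higher numbers stand for weaker inhibition of growth and lower numbers for stronger inhibition of growth. In this assay compound 1 gives 195000 nM, the highest of the two numbers reported. Compound 3 `Cc1ccc(C2=NN(C(=S)Nc3ccccc3)C(c3ccc4c(c3)OCCO4)C2)cc1C`, with 3,4-dimethylphenyl in place of 4-chlorophenyl on that carbon, gives 61300 nM; the step of a 3.2-fold lower number from compound 1 to compound 3 (0.50 log units; beyond the scatter) is modest but beyond the scatter. Compound 2 `S=C(Nc1ccccc1)N1N=C(c2ccccc2Br)CC1c1ccc2c(c1)OCCO2`, with 2-bromophenyl on that carbon, gives > 200000 nM, which is a limit of the assay rather than a number (the limit of > 200000 nM in this assay, at which 1 of the 3 values shown sits). The step of an at least 1.0-fold higher number from compound 1 to compound 2 (0.01 log units; that floor lies within the scatter) therefore cannot be sized, and an at least 3.2-fold lower number from compound 2 to compound 3 (0.51 log units; beyond the scatter) sets only a floor.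

Compound 4 `S=C(Nc1ccccc1)N1N=C(c2ccc(OCc3ccccc3)cc2)CC1c1ccc2c(c1)OCCO2` differs from compound 1 at the same aryl: benzyloxy in place of chloro on an aromatic carbon. Within the data shown here, no measured step exchanges a halogen for benzyloxy. Among the measured compounds shown here, the only sized step at this aryl, a 3.2-fold lower number from compound 1 to compound 3 (0.50 log units; beyond the scatter), shows that changes here move this assay by modest amounts, and an at least 1.0-fold higher number from compound 1 to compound 2 (0.01 log units; that floor lies within the scatter) shows no change beyond the scatter. A modest step in this assay, without a firm direction, is therefore expected for compound 4. Compound 4 is estimated at 120000 nM in this assay, between 40000 nM and 200000 nM, which means an expected step of a 1.6-fold lower number from compound 1 to compound 4 (0.21 log units; within the scatter).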

Compound 4, concentration for 50% growth inhibition: 350 nM
Estimate against measurement, compound 4: 340-fold (2.54 log units) above; measured number below the stated range.
By their numbers in this assay, from the lowest: compound 4; then compound 3; then compound 1. At a limit, above all of these: compound 2.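

In this assay, within the data shown here, this aryl position proves able to carry far larger changes than the earlier compounds showed: the only sized step so far was modest, whereas benzyloxy in place of chloro gives a 560-fold lower number from compound 1 to compound 4 (2.75 log units; beyond the scatter), a large step. The change brings in a second six-membered aromatic ring of carbon only and a hydrogen-bond acceptor, on an aromatic carbon para to a large group, so replacing a single halogen with this larger group is the one change shown here that moves the value by a large amount. The measurements shown do not identify which feature of the benzyloxy group accounts for the size of this step.

A methoxy group or a benzyl group at the same place would help to separate the contribution of the ether oxygen from that of the added ring, while a longer chain between oxygen and ring would test how far that ring may lie from the aryl. As far as these compounds go, it also remains open whether an amine or a carboxylic acid on the added ring would preserve the low value of compound 4, 350 nM.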